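Swapping a thiophene for a bromophenyl on the shared core

The source may report more compounds than this note shows. Statements on the series, on what has been measured and on what is new or still open speak of the compounds shown alone.

This study measures how strongly a set of compounds halts the growth of a human prostate cancer cell line, using a functional assay on DU-145 cells (Homo sapiens) for inhibition, read by trypan blue exclusion, with a stated time of 96 h; on this read-out lower numbers stand for stronger inhibition of growth and higher numbers for weaker inhibition of growth. Compound 1, with the structure `Cc1ccc(CS/C(=C/c2ccc(C)s2)C(=O)c2ccc(Cl)cc2)cc1`, gives 50000 nM in this assay, the highest of the two numbers recorded so far. Its nearest neighbour is compound 2, with the structure `COc1ccccc1/C=C(\C(=O)c1ccc(Cl)cc1)S(=O)(=O)c1ccc(C)cc1`, which in this assay gives 1000 nM, a number far enough below that of compound 1 to sit well outside the usual scatter. Among the compounds with values here, compound 2 differs from compound 1 in more than one place, so no single structural step between the two can be read off.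

Compound 3, with the structure `Cc1ccc(CS/C(=C/c2ccc(Br)cc2)C(=O)c2ccc(Cl)cc2)cc1`, has not yet been measured. It differs from compound 1 in one place: 4-bromophenyl in place of 5-methylthiophen-2-yl on a double-bonded chain carbon bound to a double-bonded chain carbon. Within the data shown here, since no single-change step is available among the measured compounds, the direction of this change is uncertain, and only a small step beyond the scatter, if any, is expected from compound 1 to compound 3, namely a 2.0-fold lower number from compound 1 to compound 3 (0.30 log units; within the scatter). Compound 3 is therefore expected to give about 25000 nM in this assay, with a range from 5000 nM to 100000 nM.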

Compound 3, concentration for 50% growth inhibition: 10000 nM
Beside the measured number, compound 3's estimate is 2.5-fold (0.40 log units) above it; low and high end bracket the measured number.
By their numbers in this assay, from the lowest: compound 2; then compound 3; then compound 1.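

In this assay, putting 4-bromophenyl in place of 5-methylthiophen-2-yl on a double-bonded chain carbon bound to a double-bonded chain carbon gives a 5.0-fold lower number from compound 1 to compound 3 (0.70 log units; beyond the scatter), and a lower number here means stronger inhibition of growth. Within the data shown here, this is the first step in the set that can be tied to a single place, as the two earlier compounds differ in more than one. It shows that changing the group at this position alone, with the rest of the shared core held constant, can move the result by more than the usual scatter, although the step is modest in size. Nothing available explains why this change has this effect.

The ring and the group on it change together in this step, and the compounds shown leave open which of the two carries the effect. An unsubstituted phenyl ring or a thiophene carrying bromine would help to separate them, while a phenyl ring carrying an amine or a carboxylic acid would show how far this position accepts a very different group.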